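Notes on the step from compound 1 to compound 4

This account rests on a few compounds, and the source may have more. Where it says the series, first, only, none or still open, it means among the compounds named here.

In an ADME assay on GES1 cells (Homo sapiens) for cytotoxicity, read by MTT assay, with a stated time of 24 h (on this read-out higher numbers stand for lower toxicity in this test and lower numbers for higher toxicity in this test), compound 1 (`CC1(C)[C@H]2CC[C@]1(C)N(Cc1cn(-c3ccccc3F)nn1)C(=O)C2`) gives 5160 nM and sits at the low end of the three numbers, alongside compound 2 (`CC1(C)[C@H]2CC[C@]1(C)N(Cc1cn(-c3ccccc3Cl)nn1)C(=O)C2`) at 5370 nM and well short of compound 3 (`CC1(C)[C@H]2CC[C@]1(C)N(Cc1cn(-c3cccc(Cl)c3)nn1)C(=O)C2`) at 69800 nM on this scale. Compound 4 (`CC1(C)[C@H]2CC[C@]1(C)N(Cc1cn(-c3cccc(Br)c3)nn1)C(=O)C2`) carries 3-bromophenyl in place of 2-fluorophenyl on an aromatic nitrogen. Chloro in place of fluoro gives a 1.0-fold higher number from compound 1 to compound 2 (0.02 log units; within the scatter) and so offers no guide. Among the measured compounds shown here, the useful steps are a 14-fold higher number from compound 1 to compound 3 (1.13 log units; beyond the scatter) and a 13-fold higher number from compound 2 to compound 3 (1.11 log units; beyond the scatter) since 3-chlorophenyl is the nearest measured group to 3-bromophenyl, though no bromo compound has a number yet. A large rise is therefore expected in this assay, estimated as a 12-fold higher number from compound 1 to compound 4 (1.07 log units; beyond the scatter) in size. Compound 4 is estimated at 60000 nM within an expected range of 20000 nM to 150000 nM in this test.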

Compound 4, half-maximal cytotoxic concentration: 9930 nM
Compound 4: middle estimate off by 6.0-fold (0.78 log units), on the high side; the measured number lies below the stated range.
By their numbers in this assay, from the lowest: compounds 1, 2 and 4 (each within the scatter of the next); then compound 3.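

In this assay, bromo in place of chloro on the aromatic carbon gives a 7.0-fold lower number from compound 3 to compound 4 (0.85 log units; beyond the scatter) and shows that the large rise seen with 3-chlorophenyl does not extend to 3-bromophenyl. The steps of a 1.9-fold higher number from compound 1 to compound 4 (0.28 log units; within the scatter) and a 1.8-fold higher number from compound 2 to compound 4 (0.27 log units; within the scatter) both lie within the scatter, so compound 4 groups with the 2-fluorophenyl and 2-chlorophenyl compounds and compound 3 stands alone. No measurement here accounts for the gap between the two halogens. On these data alone, whether 3-methoxyphenyl or 3-aminophenyl would read like compound 3 or like compound 4 remains open.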